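A few compounds are considered here, and "the series" means these few. Any claim that something is new, unique, unknown or untested is made for them only; others in the source may bear on it.

For the measured compounds named here, compound 3 `CC(C)OCCOC(=O)c1cccc(-c2cc(C(=O)Nc3ccncc3F)ccc2CN)c1` is one of three compounds measured in an assay on isolated protein for inhibition of Rho-associated protein kinase 2 (Homo sapiens), read by radiometric assay; on this read-out lower numbers stand for stronger inhibition and higher numbers for weaker inhibition. Compound 3 gives 37 nM, the highest number of the three. Compound 1 `NCc1ccc(C(=O)Nc2ccncc2F)cc1-c1cccc(C(=O)Oc2ccccc2)c1` gives 6.2 nM in this assay, and compound 2 `NCc1ccc(C(=O)Nc2ccncc2F)cc1-c1cccc(C(=O)OCC2CCCO2)c1` gives 2.5 nM. The three differ only in the group sitting on the oxygen next to the carbonyl group, and the measured steps are a 2.5-fold lower number from compound 1 to compound 2 (0.39 log units; beyond the scatter), a 6.0-fold higher number from compound 1 to compound 3 (0.78 log units; beyond the scatter) and a 15-fold higher number from compound 2 to compound 3 (1.17 log units; beyond the scatter).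

Compound 4 `NCc1ccc(C(=O)Nc2ccncc2F)cc1-c1cccc(C(=O)OCC2CCCCO2)c1` has not yet been measured. It differs from compound 3 in one place: oxan-2-yl in place of isopropoxymethyl on a saturated chain carbon bound to an oxygen next to a carbonyl group. Of the measured steps, the one that bears most on this change is a 15-fold higher number from compound 2 to compound 3 (1.17 log units; beyond the scatter), where an oxolan-2-yl ring was exchanged for the open isopropoxymethyl chain at the same place; compound 4 puts a ring back, now a six-membered one. A step of comparable size in the opposite direction, towards a lower number in this assay, is therefore expected. The estimate for compound 4 is 4 nM, with a range from 1.5 nM to 12 nM, which means an expected 9.3-fold lower number from compound 3 to compound 4 (0.97 log units; beyond the scatter).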

Compound 4, half-maximal inhibitory concentration: 12 nM
Compound 4: the middle estimate sits 3.0-fold (0.48 log units) below what was measured; measured number inside the range.
By their numbers in this assay, from the lowest: compound 2; then compounds 1 and 4 (each within the scatter of the next); then compound 3.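

In this assay, a ring on this saturated chain carbon again beats the open isopropoxymethyl chain, with a 3.1-fold lower number from compound 3 to compound 4 (0.49 log units; beyond the scatter) here, so this advantage is not confined to oxolan-2-yl. The ring's size also matters, since oxan-2-yl does not match the smaller ring and there is a 4.8-fold higher number from compound 2 to compound 4 (0.68 log units; beyond the scatter) in this assay. The aromatic phenyl and the saturated (oxan-2-yl)methyl cannot be told apart, with a 1.9-fold higher number from compound 1 to compound 4 (0.29 log units; within the scatter) lying within the usual scatter.

A cyclohexylmethyl group, with a carbon in place of the ring oxygen, would be needed to test whether that oxygen contributes or the ring alone is enough. What lies behind the differences between these groups remains unexplained, as no supporting data accompany these numbers.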